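The source may hold more compounds than are shown below. What is called first, only, known or untested is meant among the compounds shown, and "the series" means these compounds.

Compound 1 `OCC#CCSc1cnc2ccccc2c1SCC#CCCl` is the starting point of this account. In a functional assay on B16 cells (Mus musculus) for antiproliferative activity, with a stated time of 72 h (on this read-out lower numbers stand for stronger inhibition and higher numbers for weaker inhibition), compound 1 gives 43.4 ug/mL, the highest of the three numbers recorded. Compound 2 `CSc1cnc2ccccc2c1SCC#CCCl` gives 16.9 ug/mL, and compound 3 `CSc1cnc2ccccc2c1[Se]CC#CCOC(=O)/C=C/c1ccccc1` gives 3.1 ug/mL; compound 2 lies nearest to compound 1 and compound 3 furthest, with the gap to compound 3 well beyond the scatter. Among the measured compounds shown here, the one measured step that runs from compound 1 is a 2.6-fold lower number from compound 1 to compound 2 (0.41 log units; beyond the scatter), but it concerns a different part of the molecule and does not touch the sulfur that is now in question.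

Compound 4 `OCC#CCSc1cnc2ccccc2c1[Se]CC#CCCl` differs from compound 1 in one place: a group of 6 heavy atoms (4 carbon, 1 chlorine, 1 selenium; no ring) in place of a group of 6 heavy atoms (4 carbon, 1 sulfur, 1 chlorine; no ring), on an aromatic carbon. For the measured compounds named here, no measured pair isolates this exchange. Compound 3, which carries selenium at that aromatic carbon, shows a lower number than compound 2, yet the two differ in more than one place, so that comparison only hints at the direction. Because compound 3 gives 3.1 ug/mL, a somewhat lower number for compound 4 is expected, with wide uncertainty. The step expected is a 1.7-fold lower number from compound 1 to compound 4 (0.24 log units; within the scatter). Compound 4 is therefore estimated at 25 ug/mL in this assay, within a range from 10 ug/mL to 60 ug/mL.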

Compound 4, concentration for 50% inhibition: 3.8 ug/mL
Compound 4: the middle estimate sits 6.6-fold (0.82 log units) above what was measured; measured number below the stated range.
By their numbers in this assay, from the lowest: compounds 3 and 4 (each within the scatter of the next); then compound 2; then compound 1.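

Among the compounds shown here, compound 4 supplies the first measured pair that isolates this exchange on the aromatic carbon opposite the ring nitrogen: in this assay the change brings an 11-fold lower number from compound 1 to compound 4 (1.06 log units; beyond the scatter) and is a large step. The hint that earlier rested only on a pair differing in more than one place now stands on a change in one place, and it shows that this position does not tolerate the exchange silently, even though the two groups match in heavy-atom count and in their one triple bond and differ only in selenium for sulfur and in the count of hydrogen-bond acceptors. Nothing available here gives a measured reason for the size of this step.

The compounds shown leave open whether the same exchange gives a step of like size when the other chain is the shorter one of compound 2 rather than the chain carrying 3-hydroxyprop-1-yn-1-yl. They also leave open what an oxygen atom at this position, or an amine in place of the chlorine at the end of the chain, would do to the number.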